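The source may report more compounds than this note shows. Statements on the series, on what has been measured and on what is new or still open speak of the compounds shown alone.

Measured so far:
compound 1 `N[C@H]1CC[C@H](Nc2c(C(=O)NCc3ccco3)nc(Br)c3cccnc23)CC1`: in a functional assay on MDA-MB-435 cells (Homo sapiens) for cytotoxicity, read by MTT assay, with a stated time of 72 h (a higher number here means a weaker inhibitor, a lower number a stronger inhibitor), compound 1 gives > 10000 nM, which is a limit of the assay rather than a number.
compound 2 `Nc1ccc(Nc2c(C(=O)NCc3ccc(F)cc3)nc(Br)c3cccnc23)cc1`: in this assay compound 2 gives 7000 nM.
compound 3 `N[C@H]1CC[C@H](Nc2c(C(=O)NCc3ccc(F)cc3)nc(N3CCCCC3)c3cccnc23)CC1`: in this assay compound 3 gives 5000 nM.

Compound 2 holds the higher of the two numbers shown, with compound 3 nearest; the gap between the two lies within the usual scatter, so no order between them is claimed. Compound 1 stands at the limit described by the limit of > 10000 nM in this assay, at which 1 of the 3 values shown sits.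

Compound 4 `CNc1c(C(=O)NCc2ccc(F)cc2)nc(Br)c2cccnc12` is not yet measured. Against compound 2 the change is methyl in place of 4-aminophenyl on a nitrogen on an aromatic ring. Going by the values given here, no pair of measured compounds isolates a change of this kind, so the expectation rests only on the weak numbers of the series as a whole. The expected step of a 1.4-fold higher number from compound 2 to compound 4 (0.15 log units; within the scatter) is small, towards a higher number, and at most just beyond the scatter. For compound 4 in this assay the estimate is 10000 nM, with a range from 4000 nM to 25000 nM, and a limit in place of a number is a real possibility.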

Compound 4, half-maximal inhibitory concentration: > 20000 nM
Compound 4 was reported as a limit (the forecaster's own chance of this, stated with the estimate: 45%); middle value at least 2.0-fold (0.30 log units) away from the limit.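

In this assay compound 4 gives > 20000 nM, which is a limit of the assay and not a number. Methyl in place of 4-aminophenyl on a nitrogen on an aromatic ring gives an at least 2.8-fold higher number from compound 2 to compound 4 (0.45 log units; beyond the scatter); this is the first change in one place that can be read in the series, and it shows that the group at this nitrogen matters even at these weak values. The size of the step is open at its upper end: the limit of > 20000 nM in this assay, at which 1 of the 4 values shown sits.

On these data alone, whether the difference rests with the aromatic ring or with its amine remains open, and plain phenyl on this nitrogen would separate the two. Also open, as far as these compounds go, is whether a longer alkyl chain, such as n-butyl, behaves like methyl or like 4-aminophenyl.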